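A few compounds are considered here, and "the series" means these few. Any claim that something is new, unique, unknown or untested is made for them only; others in the source may bear on it.

Measured in an ADME assay on HeLa cells (Homo sapiens) for cytotoxicity, read by MTT assay; a higher number here means a weaker inhibitor, a lower number a stronger inhibitor:

Compound 1 `COc1ccc(C[C@H]2COC(=O)[C@@H]2Cc2ccc(OCc3cn(-c4ccc(C)cc4)nn3)c(OC)c2)cc1OC`: >= 600000 nM, a limit of the assay and not a number
Compound 2 `COc1ccc(C[C@H]2COC(=O)[C@@H]2Cc2ccc(OCc3cn(Cc4ccccc4Cl)nn3)c(OC)c2)cc1OC`: 84500 nM

For the measured compounds named here, compound 2 holds the only actual number in this assay. Compound 3 `COc1ccc(C[C@H]2COC(=O)[C@@H]2Cc2ccc(OCc3cn(-c4ccc(Cl)cc4)nn3)c(OC)c2)cc1OC` differs from it in one place: 4-chlorophenyl in place of 2-chlorobenzyl on an aromatic nitrogen. In words, 4-chlorophenyl stands in place of 2-chlorobenzyl on an aromatic nitrogen.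

Going by the values given here, the one measured step that bears on this is an at least 7.1-fold lower number from compound 1 to compound 2 (0.85 log units; beyond the scatter). That step brought in 2-chlorobenzyl in place of 4-methylphenyl. Compound 3 gives up the 2-chlorobenzyl again, so a sizeable part of that step is expected to reverse, toward a higher number in this assay. No measurement compares 4-chlorophenyl with 4-methylphenyl, so the expectation stays broad. The expected step is a 3.6-fold higher number from compound 2 to compound 3 (0.55 log units; beyond the scatter). Compound 3 is estimated at 300000 nM, with an expected range of 110000 nM to 800000 nM.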

Compound 3, half-maximal inhibitory concentration: 279000 nM
The estimate for compound 3 lay 1.1-fold (0.03 log units) above the measured number; the range from low to high includes it.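

In this assay, the change on the aromatic nitrogen gives a 3.3-fold higher number from compound 2 to compound 3 (0.52 log units; beyond the scatter). Both groups carry one chlorine, so the presence of a chlorine alone does not set the number at this position. A smaller change within the phenyl series also counts, with chloro in place of methyl on an aromatic carbon giving an at least 2.1-fold lower number from compound 1 to compound 3 (0.33 log units; beyond the scatter). Compound 1 stands at a limit of the assay and not at a number, so this second step has only a bound on its size: the limit of >= 600000 nM in this assay, at which 1 of the 3 values shown sits.

The step from 2-chlorobenzyl to 4-chlorophenyl changes benzyl to phenyl and also moves the chlorine, so the compounds shown cannot separate these two changes. A 4-chlorobenzyl or 2-chlorophenyl group would pull them apart, and an amine or carboxylic acid on that ring remains an open question.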